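An Ethoxy Swap in a Series Without Numbers

The source may report more compounds than this note shows. Statements on the series, on what has been measured and on what is new or still open speak of the compounds shown alone.

These compounds share one core and differ in the group on an amine nitrogen: compound 1 `O=C1C=C(NCc2ccccc2)C(=O)c2c1nc1n2[C@H]2OC[C@@H](O)[C@H]2OC1` carries benzyl, compound 2 `O=C1C=C(NC2CCCC2)C(=O)c2c1nc1n2[C@H]2OC[C@@H](O)[C@H]2OC1` cyclopentyl and compound 3 `O=C1C=C(Nc2ccc(C(F)(F)F)cc2)C(=O)c2c1nc1n2[C@H]2OC[C@@H](O)[C@H]2OC1` 4-(trifluoromethyl)phenyl. In a functional assay on MCF7 cells (Homo sapiens) for inhibition, read by sulforhodamine B assay (on this read-out higher numbers stand for weaker inhibition and lower numbers for stronger inhibition), compound 1 gives > 8000 nM, which is a limit of the assay and not a number. In this assay, compound 2 gives > 16000 nM, which is also a limit. In this assay, compound 3 gives > 4000 nM, again a limit. Compound 3 therefore has no measured number and cannot be ranked against the other two.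

Compound 4 `CCOc1ccccc1NC1=CC(=O)c2nc3n(c2C1=O)[C@H]1OC[C@@H](O)[C@H]1OC3` changes the same position, with 2-ethoxyphenyl in place of 4-(trifluoromethyl)phenyl on an amine nitrogen. Three measured changes at this nitrogen bear on it: a step that the two limits leave unreadable from compound 1 to compound 2, a step that the two limits leave unreadable from compound 1 to compound 3 and a step that the two limits leave unreadable from compound 2 to compound 3. Going by the values given here, none of them has a size that can be carried over, so no step of known size can be predicted in this assay. Another limit is the likeliest report for compound 4. The expected step that the limit leaves unreadable from compound 3 to compound 4 is only a rough estimate, leaning towards weaker inhibition. For compound 4 the estimated value is 10000 nM, with an expected range from 3000 nM to 30000 nM.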

Compound 4, half-maximal inhibitory concentration: > 4000 nM
Compound 4 was reported as a limit (the forecaster's own chance of this, stated with the estimate: 75%); the middle value is on the limit's open side.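

In this assay compound 4 gives > 4000 nM, which is a limit and not a number. Going by these compounds alone, compound 1, compound 2 and compound 3 are also reported only as limits, so no step from any of them to compound 4 can be read. As far as these compounds go, it remains open how these four groups on the amine nitrogen rank against one another.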